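Working notes: replacing the 3-ethoxy-4-hydroxyphenyl group of compound 1

The source may hold more compounds than are shown below. What is called first, only, known or untested is meant among the compounds shown, and "the series" means these compounds.

Measured in a functional assay on DU-145 cells (Homo sapiens) for inhibition, read by trypan blue exclusion, with a stated time of 96 h; a lower number here means a stronger inhibitor of growth, a higher number a weaker inhibitor of growth:
- compound 1 `CCOc1cc(/C=C(\C(=O)c2ccc(Cl)cc2)S(=O)(=O)Cc2ccc(Cl)cc2)ccc1O`: 10000 nM
- compound 2 `Cc1ccc(C)c(/C=C(/Sc2ccc(Br)cc2)C(=O)c2ccc(Cl)cc2)c1`: 10000 nM
- compound 3 `COc1cc(OC)c(/C=C(\C(=O)c2ccc(Cl)cc2)S(=O)(=O)c2ccc(Br)cc2)c(OC)c1`: > 100000 nM (a limit of the assay)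

Compound 1 stands level with compound 2 at the digits reported, within the scatter. The entry for compound 3 is a limit, so only two of the three entries are numbers.

The next compound is compound 4 `CSc1ccc(/C=C(\C(=O)c2ccc(Cl)cc2)S(=O)(=O)Cc2ccc(Cl)cc2)cc1`, which carries 4-(methylsulfanyl)phenyl in place of 3-ethoxy-4-hydroxyphenyl on a double-bonded chain carbon bound to a double-bonded chain carbon. For the measured compounds named here, no measured pair in the set differs in one place, so no step calibrates this change. With compound 1 at 10000 nM and compound 2 at 10000 nM, the expectation stays near that shared level, with no direction favoured in this assay. The expected change is no change at the digits printed from compound 1 to compound 4 (within the scatter), none beyond the scatter. For compound 4 the estimated value is 10000 nM, with an expected range of 2500 nM to 50000 nM.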

Compound 4, concentration for 50% growth inhibition: 10000 nM
For compound 4 middle estimate and measured number coincide at the digits printed; low and high end bracket the measured number.
By their numbers in this assay, from the lowest: compounds 1, 2 and 4 (each within the scatter of the next). At a limit, above all of these: compound 3.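

For the compounds shown here, the first step that can be read in this assay is no change at the digits printed from compound 1 to compound 4 (within the scatter), with 4-(methylsulfanyl)phenyl in place of 3-ethoxy-4-hydroxyphenyl on a double-bonded chain carbon bound to a double-bonded chain carbon. The group that enters has 0 hydrogen-bond donors and 1 hydrogen-bond acceptor, against 1 hydrogen-bond donor and 2 hydrogen-bond acceptors for the group that leaves, and this exchange leaves the read-out within the scatter. Nothing measured in this set gives a cause for that result.

From the compounds shown here alone, whether the same holds at this place for a quite different group, such as an amine or a carboxylic acid, remains open. The ethoxy and the hydroxy of the group that leaves also remain unseparated, as a phenyl carrying only one of the two would be needed to read them apart.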